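The compounds below may be only part of what the source reports. "The series", "measured", "known", "first", "only" and "open" are said of these compounds alone.

Compound 1 `C=CC[n+]1cn(C)c2nc[nH]/c(=N\OC)c21`; compound 2 `CO/N=c1\[nH]cnc2c1[n+](C/C=C(\C)CCC=C(C)C)cn2C`.

In a functional assay on CEM/s cells (Homo sapiens) for cytotoxicity (on this read-out lower numbers stand for stronger inhibition and higher numbers for weaker inhibition), compound 1 reaches only a limit of the assay, > 80000 nM. In this assay compound 2 gives 27400 nM, the only true number shown. The value of compound 1 is a limit (the limit of > 80000 nM in this assay, at which 1 of the 2 values shown sits). Compound 3 `CO/N=c1\[nH]cnc2c1[n+](C/C=C(\C)CC/C=C(\C)CCC=C(C)C)cn2C` differs from compound 2 by 3-methylbut-2-en-1-yl in place of hydrogen on a saturated chain carbon bound to a double-bonded chain carbon. Among the measured compounds shown here, no measured pair shows this change, so its size remains open. The step of a 2.3-fold lower number from compound 2 to compound 3 (0.36 log units; beyond the scatter) is expected to lower the number beyond the usual scatter. For compound 3 the estimate is 12000 nM, with a range from 4000 nM to 40000 nM.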

Compound 3, half-maximal inhibitory concentration: 1160 nM
Compound 3: middle estimate off by 10-fold (1.01 log units), on the high side; the measured number lies below the stated range.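

In this assay, 3-methylbut-2-en-1-yl in place of hydrogen on a saturated chain carbon bound to a double-bonded chain carbon gives a 24-fold lower number from compound 2 to compound 3 (1.37 log units; beyond the scatter). This is the only step shown between measured compounds, and it shows that this position tolerates further chain and that the added group moves the read-out well beyond the scatter. Nothing shown here bears on the cause of this step. From the compounds shown here alone, whether a still longer chain would lower the number further stays open, as does the effect of an amine or a carboxylic acid in place of this 3-methylbut-2-en-1-yl.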